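Two Ether Swaps on a Shared Core, Judged by Cytotoxicity

The source may hold more compounds than are shown below. What is called first, only, known or untested is meant among the compounds shown, and "the series" means these compounds.

Compound 1 `CCOC(=O)c1c(-c2cccc(OC(C)C)c2)[nH]c2cc(OC)ccc2c1=O` was tested in an ADME assay on BJ cells (Homo sapiens) for cytotoxicity, read by luminescence, with a stated time of 72 h; on this read-out higher numbers stand for an effect only at larger amounts of compound and lower numbers for an effect already at smaller amounts. In this assay compound 1 gives only a limit, > 21500 nM, and no number. Compound 2 `CCOC(=O)c1c(-c2cccc(OC(F)(F)F)c2)[nH]c2cc(OC)ccc2c1=O` differs from it by trifluoromethyl in place of isopropyl on an oxygen on an aromatic ring. In this assay compound 2 also gives only a limit, > 21500 nM. The step from compound 1 to compound 2 is therefore a step that the two limits leave unreadable from compound 1 to compound 2, so no size can be drawn from this pair.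

Compound 3 `CCOC(=O)c1c(-c2cccc(OC)c2)[nH]c2cc(OC(C)C)ccc2c1=O` carries the same groups as compound 1 but joined differently; the difference between the two cores is not broken down here. In this assay compound 3 gives only a limit, > 21500 nM, as well.

Compound 4 `CCOC(=O)c1c(-c2cccc(OC)c2)[nH]c2cc(OC(F)(F)F)ccc2c1=O` has not yet been measured in this assay. It differs from compound 3 by trifluoromethyl in place of isopropyl on an oxygen on an aromatic ring. The place of this change is the same, word for word, as in the pair of compound 1 and compound 2, so it is the same change made on a different core.

The whole picture so far is the limit of > 21500 nM in this assay, at which 3 of the 3 values shown sit. Compound 4 is expected to behave the same way, a step that the limit leaves unreadable from compound 3 to compound 4 being expected because of the limit of > 21500 nM in this assay, at which 3 of the 3 values shown sit. In this assay compound 4 is estimated to give about 30000 nM, most likely reported again only as a limit, with a range of 15000 nM to 80000 nM.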

Compound 4, half-maximal effective concentration: > 21500 nM
Compound 4: only a limit was reported (the forecaster's own chance of this, stated with the estimate: 85%); the middle value is on the limit's open side.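

Compound 4, like compound 3, is reported only as a limit in this assay, so the step from compound 3 to compound 4 cannot be read and gives no size for trifluoromethyl in place of isopropyl. The compounds shown leave open at what concentration any of them would show an effect on these cells, and whether this change matters on either core.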